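A Third Methoxy Group Added to Compound 2

This account rests on a few compounds, and the source may have more. Where it says the series, first, only, none or still open, it means among the compounds named here.

Compound 2 `COc1ccc([C@H]2CC(C)(O)[C@@H]3CC[C@@H](C)C[C@H]3O2)c(OC)c1` carries two methoxy groups on its aryl ring. In an ADME assay on MDCK cells (Canis lupus familiaris) for cytotoxicity, read by MTT assay, with a stated time of 48 h (a lower number here means that less compound is tolerated, a higher number that more compound is tolerated), compound 2 gives > 937000 nM, which is a limit of the measurement and not a number. Compound 1 `COc1ccc([C@H]2CC(C)(O)[C@@H]3CC[C@@H](C)C[C@H]3O2)cc1`, with a single methoxy group, gives 689000 nM in this assay. The step of an at least 1.3-fold higher number from compound 1 to compound 2 (0.13 log units; that floor lies within the scatter) is thus read only as a floor and stays within the scatter. Compound 3 `COc1cc(OC)c([C@H]2CC(C)(O)[C@@H]3CC[C@@H](C)C[C@H]3O2)cc1OC`, which carries three methoxy groups, gives > 857000 nM in this assay, again a limit. The step that the two limits leave unreadable from compound 2 to compound 3 cannot be sized because the limit of > 937000 nM in this assay, at which 1 of the 3 values shown sits, and the limit of > 857000 nM in this assay, at which 1 of the 3 values shown sits, cap both of its ends.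

Compound 4 `COc1cc(OC)c([C@H]2CC(C)(O)[C@@H]3CC[C@@H](C)C[C@H]3O2)c(OC)c1` differs from compound 2 by methoxy in place of hydrogen on an aromatic carbon. For the measured compounds named here, the one readable step that added a methoxy group, from compound 1 to compound 2, lay within the scatter, and the second such step left no reading at all; nothing among the three measured compounds points to a change beyond the scatter in this assay. Compound 4 is therefore expected to give about 950000 nM in this assay, with a range from 450000 nM to 2000000 nM. The expected step that the limit leaves unreadable from compound 2 to compound 4 is estimated to lie within the scatter, and most likely compound 4 will again return only a limit.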

Compound 4, half-maximal cytotoxic concentration: 856000 nM
Compound 4: the middle estimate sits 1.1-fold (0.05 log units) above what was measured, within the range that was stated.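

In this assay, a methoxy group in place of hydrogen on this aromatic carbon, ortho to a large group and meta to two methoxy groups, gives an at least 1.0-fold lower number from compound 2 to compound 4 (0.03 log units; that floor lies within the scatter). Unlike compound 2 and compound 3, which return only limits, compound 4 gives a measured number, so this pattern of three methoxy groups has a readable value on the shared core, and adding a methoxy group at this position shows no change beyond the scatter. Even so, the step is a floor and not a size because one of its ends is a limit: the limit of > 937000 nM in this assay, at which 1 of the 4 values shown sits.

The compounds shown leave open how far the true value of compound 2 lies from that of compound 4, and so whether this methoxy group has any effect at all in this assay. They also leave open whether a different group on the same aromatic carbon, such as an amine, a carboxylic acid or a longer chain like butoxy, would move the number beyond the scatter, as every change shown here replaces hydrogen with methoxy.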